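The source may hold more compounds than are shown below. What is called first, only, known or untested is meant among the compounds shown, and "the series" means these compounds.

Compound 1 `COc1cc(N(CC(C)C)c2cccc(C(F)(F)F)c2)cnc1C(=O)[C@H]1C[C@@H]1C(=O)O` gives the lowest number of the three measured in an assay on isolated protein for inhibition of leukotriene C4 synthase (Homo sapiens), read by LC-MS, with stated times of 45 min and 20 min (a higher number here means a weaker inhibitor, a lower number a stronger inhibitor), at 20.6 nM. Compound 2 `CCCN(c1cccc(C(F)(F)F)c1)c1cnc(C(=O)[C@H]2C[C@@H]2C(=O)O)c(OC)c1` gives 58.4 nM, and compound 3 `COc1cc(N(Cc2ccc(F)cc2)c2cccc(C(F)(F)F)c2)cnc1C(=O)[C@H]1C[C@@H]1C(=O)O` gives 157 nM. The steps of a 2.8-fold higher number from compound 1 to compound 2 (0.45 log units; beyond the scatter) and a 7.6-fold higher number from compound 1 to compound 3 (0.88 log units; beyond the scatter) both alter the group on the nitrogen and leave the aryl ring untouched. Compound 4 `COc1cc(N(CC(C)C)c2cc(C(F)(F)F)ccc2F)cnc1C(=O)[C@H]1C[C@@H]1C(=O)O` differs from compound 1 by fluoro in place of hydrogen on an aromatic carbon. Within the data shown here, none of the measured steps changes this ring, so no measured step bears directly on the change, and a step within the usual scatter in this assay, in no fixed direction, is expected. The estimate for compound 4 is 20 nM, between 7 nM and 60 nM, which means an expected step of a 1.0-fold lower number from compound 1 to compound 4 (0.01 log units; within the scatter).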

Compound 4, half-maximal inhibitory concentration: 6.8 nM
Compound 4: the middle estimate sits 2.9-fold (0.47 log units) above what was measured; the whole stated range lies above it.
By their numbers in this assay, from the lowest: compound 4; then compound 1; then compound 2; then compound 3.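

Fluoro in place of hydrogen on this aromatic carbon, ortho to a large group and para to a trifluoromethyl group, gives a 3.0-fold lower number from compound 1 to compound 4 (0.48 log units; beyond the scatter). The aryl ring, the same in compound 1, compound 2 and compound 3, therefore also moves the number, not only the group on the nitrogen. Nothing available explains why this step occurs. The compounds shown leave open whether chloro or methyl on this carbon would give a similar step. They also leave open whether fluoro here would act alike with the nitrogen group of compound 2.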